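Clearance notes: tertiary carbinol replacing sulfoximine on the aryl ring

The source may report more compounds than this note shows. Statements on the series, on what has been measured and on what is new or still open speak of the compounds shown alone.

Measured in an ADME assay (liver) for metabolic stability, with Liver microsome (Rattus norvegicus) as the target, using microsomes and NADPH, with a stated time of 30 min; a higher number here means faster removal of the compound, a lower number slower removal:
- compound 1 `CC#C[C@H]1CN(S(=O)(=O)c2ccc(N)nc2)CCN1c1ccc([C@@](O)(CO)C(F)(F)F)cc1` gives 53 mL.min-1.g-1
- compound 2 `CC#C[C@H]1CN(S(=O)(=O)c2ccc(N)nc2)CCN1c1ccc(S(=O)(=NC)C(F)(F)F)cc1` gives 257 mL.min-1.g-1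
- compound 3 `CC#C[C@H]1CN(S(=O)(=O)c2ccc(N)nc2)CCN1c1ccc(C(C)=O)cc1` gives 249 mL.min-1.g-1

Compound 2 stands at the highest of the three numbers, though its gap to compound 3 is within the scatter a 1.0-fold lower number from compound 2 to compound 3 (0.01 log units; within the scatter); only compound 1 sits clearly apart from it a 4.8-fold higher number from compound 1 to compound 2 (0.69 log units; beyond the scatter).

Compound 4 `CC#C[C@H]1CN(S(=O)(=O)c2ccc(N)nc2)CCN1c1ccc(C(O)(CC#N)C(F)(F)F)cc1` is not yet measured. Its change from compound 2 is a group of 9 heavy atoms (4 carbon, 1 nitrogen, 1 oxygen, 3 fluorine; no ring) in place of a group of 8 heavy atoms (2 carbon, 1 nitrogen, 1 oxygen, 3 fluorine, 1 sulfur; no ring), on an aromatic carbon.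

Going by the values given here, the steps that bear on this are those away from compound 1: a 4.8-fold higher number from compound 1 to compound 2 (0.69 log units; beyond the scatter) and a 4.7-fold higher number from compound 1 to compound 3 (0.67 log units; beyond the scatter). Both replace the carbinol bearing trifluoromethyl and hydroxymethyl with a group lacking the carbinol, and both move the number up by a similar amount. Compound 4 restores a carbinol bearing trifluoromethyl, with a cyanomethyl arm in place of the hydroxymethyl arm of compound 1, so it is expected to sit nearer compound 1 than compound 2, as a decrease beyond the scatter a 2.9-fold lower number from compound 2 to compound 4 (0.46 log units; beyond the scatter). Compound 4 is therefore estimated at 90 mL.min-1.g-1, in the range 40 mL.min-1.g-1 to 200 mL.min-1.g-1.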

Compound 4, intrinsic clearance in microsomes: 57 mL.min-1.g-1
Compound 4: middle estimate off by 1.6-fold (0.20 log units), on the high side; measured number inside the range.
By their numbers in this assay, from the lowest: compounds 1 and 4 (each within the scatter of the next); then compounds 3 and 2 (each within the scatter of the next).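

In this assay, the cyanomethyl and hydroxymethyl arms on the trifluoromethyl carbinol cannot be told apart (a 1.1-fold higher number from compound 1 to compound 4 (0.03 log units; within the scatter)), so at this aromatic carbon the low number does not depend on the hydroxyl group of the hydroxymethyl arm. The carbinol with the cyanomethyl arm stands clearly apart from both the sulfoximine (a 4.5-fold lower number from compound 2 to compound 4 (0.65 log units; beyond the scatter)) and the acetyl group (a 4.4-fold lower number from compound 3 to compound 4 (0.64 log units; beyond the scatter)), so both carbinols now share the low number, while the two groups without a carbinol share the high one. No data here bear on why these numbers differ.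

A carbinol with a methyl group in place of trifluoromethyl would show whether the trifluoromethyl group is needed for the low number. As far as these compounds go, how a longer cyanoethyl arm, or an amine or a carboxylic acid on the arm, would read remains open.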